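The compounds below may be only part of what the source reports. "The series", "measured", "known", "first", "only" and "open" are said of these compounds alone.

Going by the values given here, compound 1, `CCOc1ccc(-c2ccc3ncn(-c4cc(OC)c(OC)c(OC)c4)c3c2)cc1`, sits in the middle of the three compounds measured so far: in a functional assay on A549 cells (Homo sapiens) for antiproliferative activity, read by MTT assay, with a stated time of 72 h (on this read-out lower numbers stand for stronger inhibition and higher numbers for weaker inhibition), compound 1 gives 8550 nM. Its closest neighbour is compound 2, `COc1cc(-n2cnc3ccc(-c4ccc([N+](=O)[O-])cc4)cc32)cc(OC)c1OC`, which in this assay gives 8940 nM, so that the step of a 1.0-fold higher number from compound 1 to compound 2 (0.02 log units; within the scatter) is one the assay cannot resolve. Among the compounds with values here, the compound furthest from it is compound 3, `COc1cc(-n2cnc3ccc(-c4ccccc4)cc32)cc(OC)c1OC`, which gives 3060 nM; the step of a 2.8-fold lower number from compound 1 to compound 3 (0.45 log units; beyond the scatter) is the only one from compound 1 that stands out from the scatter, and the parallel step a 2.9-fold lower number from compound 2 to compound 3 (0.47 log units; beyond the scatter) points the same way.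

Compound 4, `COc1cc(-n2cnc3ccc(-c4cccc(C)c4C)cc32)cc(OC)c1OC`, differs from compound 1 in one place: 2,3-dimethylphenyl in place of 4-ethoxyphenyl on an aromatic carbon. Within the data shown here, no measured step exchanges one substituted phenyl for another, so the nearest guidance comes from the two steps that strip a group from that ring, a 2.8-fold lower number from compound 1 to compound 3 (0.45 log units; beyond the scatter) and a 2.9-fold lower number from compound 2 to compound 3 (0.47 log units; beyond the scatter), both modest and both toward lower numbers. A ring that carries two methyl groups rather than nothing is not the same as a bare ring, so a smaller move in the same direction is expected. On that basis compound 4 is estimated at 4500 nM, with a range from 1500 nM to 13000 nM, a step of a 1.9-fold lower number from compound 1 to compound 4 (0.28 log units; within the scatter) that is expected to lie close to the edge of the scatter.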

Compound 4, half-maximal inhibitory concentration: 9250 nM
For compound 4 the middle estimate is 2.1-fold (0.31 log units) below the measured one, within the range that was stated.
By their numbers in this assay, from the lowest: compound 3; then compounds 1, 2 and 4 (each within the scatter of the next).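

In this assay the exchange of 4-ethoxyphenyl for 2,3-dimethylphenyl is a 1.1-fold higher number from compound 1 to compound 4 (0.03 log units; within the scatter) and the exchange of 4-nitrophenyl for the same group is a 1.0-fold higher number from compound 2 to compound 4 (0.01 log units; within the scatter), so the three substituted rings cannot be told apart at this position, even though the new ring carries two methyl groups and neither of the earlier substituents. The bare phenyl ring alone stands apart, with the change to 2,3-dimethylphenyl giving a 3.0-fold higher number from compound 3 to compound 4 (0.48 log units; beyond the scatter); across these four compounds each substituted ring therefore goes with a higher number than the unsubstituted ring, and none goes against this. No supporting measurement is available to explain why these substituted rings cannot be separated or why the bare ring stands apart.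

From the compounds shown here alone, it remains open whether a single methyl group on this ring is enough to produce the step from the bare phenyl, or whether both methyl groups are involved. Also open, going by these compounds, is whether a much smaller substituent such as fluorine, or an amine or a carboxylic acid on the same ring, would stay with the substituted rings or move toward the bare phenyl.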